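Moving the Formyl Group Around a Phenoxy Ring

The compounds below may be only part of what the source reports. "The series", "measured", "known", "first", "only" and "open" are said of these compounds alone.

Of the compounds shown here, three share one core and have been tested in an assay for inhibition of Alpha amylase (Homo sapiens), with a stated time of 30 min; on this read-out higher numbers stand for weaker inhibition and lower numbers for stronger inhibition. Compound 1 `CCOC(=O)c1c(-c2ccccc2)nn(-c2ccccc2)c1Cn1cnc2ccccc21` gives 35 ug/mL. Compound 2 `CCOC(=O)c1c(-c2ccccc2)nn(-c2ccccc2)c1Cn1cnc2cc(C)ccc21` gives 45 ug/mL. Compound 3 `CCOC(=O)c1c(-c2ccccc2)nn(-c2ccccc2)c1COc1ccc(C=O)cc1` gives 60 ug/mL. Of the three numbers, that of compound 3 is the largest, yet the gaps are small: a 1.3-fold higher number from compound 2 to compound 3 (0.12 log units; within the scatter) and a 1.7-fold higher number from compound 1 to compound 3 (0.23 log units; within the scatter), both within the scatter, as is a 1.3-fold higher number from compound 1 to compound 2 (0.11 log units; within the scatter).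

Compound 4 `CCOC(=O)c1c(-c2ccccc2)nn(-c2ccccc2)c1COc1ccccc1C=O` differs from compound 3 only in where the formyl group sits: 2-formylphenyl in place of 4-formylphenyl on an oxygen on a saturated carbon. Among the compounds with values here, none of the measured steps changes the position of a group on this ring, so nothing bears directly on the step to compound 4. All three measured steps were within the scatter, and there is no reason in these data to expect a larger effect here. The expected step is no change at the digits printed from compound 3 to compound 4 (within the scatter), with no change beyond the scatter. Compound 4 is therefore estimated at 60 ug/mL in this assay, within a range from 30 ug/mL to 120 ug/mL.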

Compound 4, half-maximal inhibitory concentration: 40 ug/mL
For compound 4 the middle estimate is 1.5-fold (0.18 log units) above the measured one; measured number inside the range.
By their numbers in this assay, from the lowest: compounds 1, 4, 2 and 3 (each within the scatter of the next).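

Moving the formyl group, in the only step here that changes a position on this ring, replaces 4-formylphenyl with 2-formylphenyl and gives a 1.5-fold lower number from compound 3 to compound 4 (0.18 log units; within the scatter) in this assay, so these two placements cannot be told apart in this assay. The 2-formylphenoxy group also cannot be separated from the other two groups on the same saturated chain carbon: the steps are a 1.1-fold lower number from compound 2 to compound 4 (0.05 log units; within the scatter) and a 1.1-fold higher number from compound 1 to compound 4 (0.06 log units; within the scatter). No supporting measurement bears on what lies behind these small steps.

With every step inside the scatter, these compounds do not show whether this ring position matters for inhibition at all. On these data alone, it remains open whether a carboxylic acid or an amine in place of the formyl group, or a plain phenoxy group with no formyl, would give a step beyond the scatter.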